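From ethylamino to anilino on the shared core

The source may report more compounds than this note shows. Statements on the series, on what has been measured and on what is new or still open speak of the compounds shown alone.

Measured in a functional assay on the whole organism with Mus musculus as the target; a higher number here means that more compound is needed for the effect, a lower number that less compound is needed:
- compound 1 `CC(=O)Nc1c(C)c(C)c2c(c1C)CC(C)(C)O2`: > 100 mg/kg
- compound 2 `CCOC(=O)Nc1c(C)c(C)c2c(c1C)CC(C)(C)O2`: > 100 mg/kg
- compound 3 `CCNc1c(C)c(C)c2c(c1C)CC(C)(C)O2`: 38.9 mg/kg

The reading for compound 1 is a limit of the assay and not a number. The reading for compound 2 is also such a limit. Going by the values given here, compound 3 therefore holds the only true number in the set, and it sits on the lower side of both limits.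

Compound 4 `Cc1c(C)c2c(c(C)c1Nc1ccccc1)CC(C)(C)O2` is the next to be tested in this assay. It has phenyl in place of ethyl on a nitrogen on an aromatic ring.

Two measured steps change the same nitrogen: an at least 2.5-fold lower number from compound 1 to compound 3 (0.41 log units; beyond the scatter) and an at least 2.5-fold lower number from compound 2 to compound 3 (0.41 log units; beyond the scatter). Both show that the group there can matter, but both lead to ethyl and neither involves phenyl. They therefore give no firm direction for the new change, and no step beyond the scatter is expected. The estimated change is a 1.1-fold lower number from compound 3 to compound 4 (0.05 log units; within the scatter). For compound 4 the expected value is 35 mg/kg, within an estimated range of 10 mg/kg to 120 mg/kg.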

Compound 4, dose for 50% inhibition: > 50 mg/kg
Compound 4 ended at the assay's limit; the forecaster's own chance of this, stated with the estimate: 30%; middle value at least 1.4-fold (0.15 log units) away from the limit.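

In this assay compound 4 gives > 50 mg/kg, which is a limit of the assay and not a number. Phenyl in place of ethyl on the nitrogen gives an at least 1.2-fold higher number from compound 3 to compound 4 (0.10 log units; that floor lies within the scatter), so the data allow a higher number for compound 4 but do not establish a real difference from compound 3. Going by these compounds alone, compound 4 has no carbonyl on this nitrogen, yet like compound 1 and compound 2 it reads only as a limit, which leaves compound 3 with the only true number, and the steps from compound 1 and compound 2 to compound 4 cannot be read.

As far as these compounds go, how far the number rises with phenyl remains open. Also open, from the compounds shown here alone, is how a propyl chain, a benzyl group or a free amine on this nitrogen would read in this assay.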